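The source may report more compounds than this note shows. Statements on the series, on what has been measured and on what is new or still open speak of the compounds shown alone.

In an assay on HEK293 cells for positive allosteric modulation of metabotropic glutamate receptor 2 (Rattus norvegicus), read by thallium flux, with a stated time of 2.5 min (on this read-out lower numbers stand for an effect already at smaller amounts and higher numbers for an effect only at larger amounts of compound), three compounds have been measured. Compound 1, with the structure `COc1cc(C(=O)O)ccc1OCCCCOc1ccc(C(=O)CC(C)(C)C)c(O)c1C`, gives 47 nM. Compound 2, with the structure `Cc1cc(OCCCCOc2ccc(C(=O)CC3CCCC3)c(O)c2C)ccc1C(=O)O`, gives 564 nM. Compound 3, with the structure `Cc1c(OCCCCOc2ccc(C(=O)O)cc2Cl)ccc(C(=O)CC(C)C)c1O`, gives 96 nM. Of these three numbers, compound 1 has the lowest; compound 3 comes nearest, and the gap between compound 1 and compound 3 lies beyond the usual scatter, while compound 2 lies furthest from compound 1, again beyond the scatter. Among the measured compounds shown here, no step between two of the measured compounds differs in only one place, so the three values stand on their own rather than as a series of single changes.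

Compound 4, with the structure `COc1cc(C(=O)O)ccc1OCCCCOc1ccc(C(=O)C(C)C)c(O)c1C`, has not yet been measured. It differs from compound 1 in one place only: isopropyl in place of neopentyl on a carbonyl carbon. The carbonyl carbon and the aromatic carbon it joins are the same in both; only the alkyl group on that carbonyl carbon changes, a group of five carbons giving way to a group of three.

For the measured compounds named here, since no measured pair shows what this change does, the expectation for compound 4 rests only on the three values at hand. Compound 4 is expected to give a somewhat higher number than compound 1, with a 2.6-fold higher number from compound 1 to compound 4 (0.41 log units; beyond the scatter), a step that may or may not exceed the scatter. The estimate for compound 4 in this assay is 120 nM, with a range from 40 nM to 400 nM.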

Compound 4, half-maximal effective concentration: 113 nM
Estimate against measurement, compound 4: 1.1-fold (0.03 log units) above; the range from low to high includes it.
By their numbers in this assay, from the lowest: compound 1; then compounds 3 and 4 (each within the scatter of the next); then compound 2.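

In this assay, among the compounds shown here, the exchange of neopentyl for isopropyl on a carbonyl carbon gives a 2.4-fold higher number from compound 1 to compound 4 (0.38 log units; beyond the scatter), the first change in this set that can be read on its own, since the compounds measured before it differed in more than one place. The step is modest but beyond the usual scatter: on the core of compound 1, the alkyl group on this carbonyl carbon affects the read-out, and the neopentyl compound has the lower number of the pair, yet the shorter isopropyl group does not abolish the effect, with compound 4 still giving 113 nM in the same assay. Nothing in the data given bears on the reason for this step.

As far as these compounds go, a single pair of branched alkyl groups gives one step and not a trend, so it remains open whether the number follows the size of the group or its shape, and how a straight butyl chain, a cyclopropyl ring or an amine on the same carbonyl carbon would read. From the compounds shown here alone, it is also open whether this step would keep its size on the cores of compound 2 and compound 3, which differ from compound 1 in more than one place.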